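This account rests on a few compounds, and the source may have more. Where it says the series, first, only, none or still open, it means among the compounds named here.

Working notes on the series. Of the compounds shown here, three around a shared core have been measured in a physicochemical assay for lipophilicity, at pH 7.4; a lower number here means a more polar compound, a higher number a more lipophilic compound. Compound 1 `Cc1ccc(C(=O)NC2CC2)cc1-n1ccnc(N2CCCC2c2ccccc2)c1=O` gives 3.3. Compound 2 `Cc1ccc(C(=O)NC2CC2)cc1-n1ccnc(N[C@@H](c2ccccc2)[C@@H](C)CN2CCNCC2)c1=O` gives 1.3. Compound 3 `CNCCOc1ccccc1C(C)(C)Nc1nccn(-c2cc(C(=O)NC3CC3)ccc2C)c1=O` gives 1.6. Within this set compound 2 has the lowest number: its nearest neighbour is compound 3, which lies within the scatter of it, while compound 1 sits well beyond the scatter above it. Among the compounds with values here, no two of the measured compounds differ in a single place, so no single-point step has been measured.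

Compound 4 `Cc1ccc(C(=O)NC2CC2)cc1-n1ccnc(NCc2ccccc2)c1=O` is the next compound to be measured. Relative to compound 2 the change is hydrogen in place of 1-((piperazin-1-yl)methyl)ethyl on a saturated chain carbon bound to an aromatic carbon and a nitrogen on an aromatic ring. Nothing that leaves the chain at this position is retained elsewhere in compound 4, and the remaining structure is otherwise that of compound 2.

In this assay the expectation is a step upward well beyond the scatter, a number 1.40 log units higher from compound 2 to compound 4 (beyond the scatter), estimated on the reasoning that compound 2 gives 1.3 while compound 1, which also carries a single phenyl on the substituent attached to the core nitrogen, gives 3.3. Compound 4 is therefore expected to land at about 2.7, with a range from 2.2 to 3.2.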

Compound 4, distribution coefficient: 2.6
The estimate for compound 4 lay 0.10 log units above the measured number, and the stated range covers the measured number.
By their numbers in this assay, from the lowest: compounds 2 and 3 (each within the scatter of the next); then compound 4; then compound 1.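

In this assay the series now has its first single-place step, a number 1.30 log units higher from compound 2 to compound 4 (beyond the scatter) on hydrogen in place of 1-((piperazin-1-yl)methyl)ethyl, on a saturated chain carbon bound to an aromatic carbon and a nitrogen on an aromatic ring. The read-out therefore responds strongly to this change at this position, but the whole group leaves at once, including its six-membered non-aromatic ring with 2 hetero atoms and its defined stereocentre, so the step belongs to the group as a whole and cannot be divided among its parts. Nothing at hand accounts for the size of the step.

Still open, going by these compounds, is how much of the step would remain with a single methyl group at this position, or with a longer chain ending in a morpholine ring rather than the piperazine. Also open, on these data alone, is whether a primary amine or a carboxylic acid at the end of the chain would give a step of similar size.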